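Fluoro for Methyl on the Triazole Aryl Ring

This account rests on a few compounds, and the source may have more. Where it says the series, first, only, none or still open, it means among the compounds named here.

Compound 1: `Cc1c(O)ccc2c1[C@H](Cn1cc(-c3ccc(F)cc3)nn1)[C@@]13CC(=O)[C@@](C)(CC[C@@H]21)C3` — in a functional assay on SW480 cells (Homo sapiens) for cytotoxicity, read by MTT assay, with a stated time of 4 days (a higher number here means a weaker inhibitor, a lower number a stronger inhibitor), compound 1 gives > 20000 nM, a limit of the assay.
Compound 2: `Cc1ccc(-c2cn(C[C@H]3c4c(ccc(OS(=O)(=O)c5ccc(C)cc5)c4C)[C@@H]4CC[C@@]5(C)C[C@]43CC5=O)nn2)cc1` — in this assay compound 2 gives > 20000 nM, a limit of the assay.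

Compound 2 stands at the limit of > 20000 nM in this assay, at which 2 of the 2 values shown sit. Both measured values are limits, so no step between measured compounds can be counted and no order between compound 1 and compound 2 is shown.

Compound 3 `Cc1ccc(S(=O)(=O)Oc2ccc3c(c2C)[C@H](Cn2cc(-c4ccc(F)cc4)nn2)[C@@]24CC(=O)[C@@](C)(CC[C@@H]32)C4)cc1` is not yet measured. It differs from compound 2 by fluoro in place of methyl on an aromatic carbon. Going by the values given here, with no measured step and both known values sitting at the limit, the expectation for this assay is a change of no more than the scatter in either direction, the estimated step being a step that the limit leaves unreadable from compound 2 to compound 3. Compound 3 is expected to give 25000 nM in this assay, within 8000 nM to 80000 nM, and most probably again reported only as a limit.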

Compound 3, half-maximal inhibitory concentration: > 20000 nM
Compound 3: only a limit was reported; the forecaster's own chance of this, stated with the estimate: 85%; the middle value is on the limit's open side.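

No step to compound 3 can be read from compound 1 or compound 2 in this assay, as all three values are limits: the limit of > 20000 nM in this assay, at which 3 of the 3 values shown sit.

Left open is whether fluoro in place of methyl, or (4-methylphenyl)sulfonyl in place of hydrogen, shifts the read-out at all.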